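The compounds below may be only part of what the source reports. "The series", "measured", "known", "first", "only" and "open" are said of these compounds alone.

Working notes on the series. Among the measured compounds shown here, compound 1 `C=CCN1C(=O)C(=O)c2cc(-c3ccc(OC)cc3)ccc21` is measured in a functional assay on K562 cells (Homo sapiens) for antiproliferative activity, read by MTT assay, with a stated time of 48 h (on this read-out lower numbers stand for stronger inhibition and higher numbers for weaker inhibition), and gives 390 nM; of the two numbers so far this is the higher one, the nearer neighbour being compound 3 `COc1ccc(CN2C(=O)C(=O)c3cc(-c4ccc(OC)cc4)ccc32)cc1`, which in this assay gives 30 nM. For the measured compounds named here, compound 2 `COc1ccc(-c2ccc3c(c2)C(=O)C(=O)N3c2ccc(OC)cc2)cc1` returns only a limit in this assay, > 10000 nM; it is the one value that sits at the limit of > 10000 nM in this assay, at which 1 of the 3 values shown sits.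

The measured steps: a 13-fold lower number from compound 1 to compound 3 (1.11 log units; beyond the scatter), an at least 25-fold higher number from compound 1 to compound 2 (1.40 log units; beyond the scatter), and an at least 330-fold lower number from compound 2 to compound 3 (2.52 log units; beyond the scatter). So within these three compounds the nitrogen substituent decides the outcome, a benzyl-type group giving the lowest number and a directly attached 4-methoxyphenyl giving only a limit.

Compound 4 `COc1ccc(-c2ccc3c(c2)C(=O)C(=O)N3Cc2cccc(OC)c2)cc1` is not yet measured. The change from compound 1 is 3-methoxyphenyl in place of vinyl on a saturated chain carbon bound to an amide-type nitrogen in a ring. The step that bears on it most closely is a 13-fold lower number from compound 1 to compound 3 (1.11 log units; beyond the scatter), where the same kind of aromatic ring enters at the same place, differing only in where the methoxy sits on that ring. A step of similar direction and size is therefore expected for compound 4, with the exact methoxy position as the open question; compound 4 is estimated to give 45 nM, ranging from 15 nM to 150 nM, i.e. the expected step is an 8.7-fold lower number from compound 1 to compound 4 (0.94 log units; beyond the scatter).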

Compound 4, half-maximal inhibitory concentration: 680 nM
The estimate for compound 4 lay 15-fold (1.18 log units) below the measured number; the measured number lies above the stated range.
By their numbers in this assay, from the lowest: compound 3; then compounds 1 and 4 (each within the scatter of the next). At a limit, above all of these: compound 2.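

Moving the methoxy on the benzyl ring is enough on its own to produce a large step in this assay: a 23-fold higher number from compound 3 to compound 4 (1.36 log units; beyond the scatter), so 4-methoxybenzyl and 3-methoxybenzyl on the ring nitrogen are not interchangeable. Exchanging allyl for 3-methoxybenzyl gives a 1.7-fold higher number from compound 1 to compound 4 (0.24 log units; within the scatter), so compounds 1 and 4 cannot be told apart, and an aromatic ring at this place does not by itself bring the gain seen with compound 3. A benzyl-type link is therefore not sufficient for that gain, although the step of an at least 14-fold lower number from compound 2 to compound 4 (1.16 log units; beyond the scatter) still separates 3-methoxybenzyl from a directly attached 4-methoxyphenyl, and that step rests on a limit rather than a number: the limit of > 10000 nM in this assay, at which 1 of the 4 values shown sits.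

The compounds shown leave open where a plain benzyl group would stand in this assay, and so whether the 4-methoxy group improves on it or the 3-methoxy group detracts from it. They also leave open whether the result for compound 3 extends to other groups on the benzyl ring, such as 4-chlorobenzyl or 4-ethoxybenzyl, or to a longer link such as 2-phenylethyl.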